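Third methoxy on the aryl imine: expected flat step

The source may hold more compounds than are shown below. What is called first, only, known or untested is meant among the compounds shown, and "the series" means these compounds.

Three measured compounds share one core and differ only on the aryl ring of the imine. Compound 1 `COc1ccc(/C=N/c2c(C)n(C)n(-c3ccccc3)c2=O)cc1` carries a single methoxy, compound 2 `COc1ccc(/C=N/c2c(C)n(C)n(-c3ccccc3)c2=O)cc1OC` two methoxy groups, and compound 3 `COc1cc(/C=N/c2c(C)n(C)n(-c3ccccc3)c2=O)ccc1O` one methoxy and one free hydroxyl. In a functional assay on HCT-116 cells (Homo sapiens) for cytotoxicity, read by MTT assay, with a stated time of 72 h (a lower number here means a stronger inhibitor, a higher number a weaker inhibitor), compound 1 gives 575000000 nM, compound 2 gives 575000000 nM and compound 3 gives 468000000 nM. Compound 2 thus stands level with compound 1 at the digits shown, the two together being the highest numbers of the three; compound 3 lies a little lower, but a 1.2-fold lower number from compound 2 to compound 3 (0.09 log units; within the scatter) is within the scatter, so no order among the three can be drawn.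

Compound 4 `COc1cc(/C=N/c2c(C)n(C)n(-c3ccccc3)c2=O)cc(OC)c1OC` differs from compound 2 by methoxy in place of hydrogen on an aromatic carbon. Among the measured compounds shown here, two measured steps bear on this move: no change at the digits printed from compound 1 to compound 2 (within the scatter), which is the same kind of change, and a 1.2-fold lower number from compound 2 to compound 3 (0.09 log units; within the scatter), both within the scatter. For the measured compounds named here, nothing among the measured compounds indicates that a further methoxy shifts this assay beyond the scatter, so the expected step is a 1.0-fold lower number from compound 2 to compound 4 (0.01 log units; within the scatter), that is, none beyond the scatter. Compound 4 is therefore estimated at 560000000 nM in this assay, with a range from 250000000 nM to 1250000000 nM.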

Compound 4, half-maximal inhibitory concentration: 525000000 nM
For compound 4 the middle estimate is 1.1-fold (0.03 log units) above the measured one; the measured number falls inside the stated range.
By their numbers in this assay, from the lowest: compounds 3, 4, 1 and 2 (each within the scatter of the next).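

Methoxy in place of hydrogen on an aromatic carbon, here ortho to a methoxy group and meta to a large group, gives a 1.1-fold lower number from compound 2 to compound 4 (0.04 log units; within the scatter) in this assay, so this position accepts a further methoxy with no step beyond the scatter. The earlier reading of the same replacement, no change at the digits printed from compound 1 to compound 2 (within the scatter), started from a ring with a single methoxy, whereas compound 4 extends it to a ring that already carries two, and the series now runs as four compounds, each within the scatter of the next. No measurement on hand bears on why this step stays so small.

Open is whether any group on this aromatic carbon moves the number beyond the scatter, as only hydrogen and methoxy are shown at this position, and an amine, a carboxylic acid or a longer alkoxy chain would put that to the test. Also open, as far as these compounds go, is whether the level of compound 4 at 525000000 nM is set by the shared core rather than by the substituents on the aryl ring of the imine.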